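Weak Kinase Inhibitors and a Lengthened Ether Side Chain

This account rests on a few compounds, and the source may have more. Where it says the series, first, only, none or still open, it means among the compounds named here.

Measured compounds:
compound 1 `Cc1[nH]c2ccccc2c1-c1ccnc(NCCO)n1` gives 11000 nM
compound 2 `OCCNc1nccc(-c2c[nH]c3ccccc23)n1` gives 11000 nM
compound 3 `C=C1NNC(=O)N=C1Nc1ccc2cn[nH]c2c1` gives 16000 nM

All three numbers come from an assay on isolated protein for inhibition of interferon-induced, double-stranded RNA-activated protein kinase (Homo sapiens), read by luminescence, with a stated time of 10 min (a lower number here means a stronger inhibitor, a higher number a weaker inhibitor), and all three sit close together. Compound 1 stands level with compound 2, and the number for compound 3 also lies within the scatter of the other two, so no ranking among them can be read from these values. Among the compounds with values here, the only single-point step among the measured compounds is no change at the digits printed from compound 1 to compound 2 (within the scatter), a hydrogen in place of a methyl on an aromatic carbon of the shared core, and it moved nothing.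

Compound 4 `COCCCNc1nccc(-c2c(C)[nH]c3ccccc23)n1` differs from compound 1 by methoxymethyl in place of hydroxy on a saturated chain carbon, two bonds along the chain from a nitrogen on an aromatic ring. Within the data shown here, no measured pair touches this side chain, so the change on the core from compound 1 to compound 2 bears on it only indirectly, by showing that the scaffold tolerates a small edit without shift. With nothing pointing either way, a step of no size beyond the scatter is expected, a 1.1-fold higher number from compound 1 to compound 4 (0.04 log units; within the scatter). Compound 4 is therefore estimated at 12000 nM, with a range from 4000 nM to 35000 nM.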

Compound 4, half-maximal inhibitory concentration: 1500 nM
Beside the measured number, compound 4's estimate is 8.0-fold (0.90 log units) above it, and the stated range ends above it.
By their numbers in this assay, from the lowest: compound 4; then compounds 1, 2 and 3 (each within the scatter of the next).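

In this assay the change from (2-hydroxyethyl)amino to (3-methoxypropyl)amino gives a 7.3-fold lower number from compound 1 to compound 4 (0.87 log units; beyond the scatter) and so shows that this side chain, unlike the methyl on the shared core, is a place where a single edit moves the number beyond the scatter. The one edit does two things at once, adding to the chain's heavy atoms and replacing the hydroxy with a group that has no hydrogen-bond donor, and the pair cannot tell these apart. No measurement shown here explains the gain.

The compounds shown leave open whether the lengthening or the capping of the hydroxy carries the step, which a 3-hydroxypropyl or a 2-methoxyethyl group would help separate. They also leave open whether a terminal amine or a longer ether chain would go further, and whether the same step holds on the core of compound 2.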